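Shortening the Alkyne Chain from Compound 3 to Compound 4

The source may hold more compounds than are shown below. What is called first, only, known or untested is meant among the compounds shown, and "the series" means these compounds.

Compound 1 is `Cc1ccc(-c2cc(C)oc(=O)c2)cc1`; in a functional assay on K562 cells (Homo sapiens) for inhibition (a higher number here means a weaker inhibitor, a lower number a stronger inhibitor), compound 1 reaches only the assay limit of > 50000 nM.
Compound 2 is `C#Cc1cc(C)oc(=O)c1`; in this assay compound 2 gives 2000 nM.
Compound 3 is `CCCCCCC#Cc1cc(C)oc(=O)c1`; in this assay compound 3 gives 20300 nM.

Among the two actual numbers, compound 3 stands highest, with compound 2 the nearest and clearly lower, a gap beyond the scatter. Compound 4 is `CCCC#Cc1cc(C)oc(=O)c1` and differs from compound 3 by hydrogen in place of propyl on a saturated chain carbon, three bonds along the chain from a triple-bonded carbon. Going by the values given here, no step between measured compounds is available, so the expectation rests on compound 2, whose bare alkyne gives 2000 nM and sits well below compound 3. Shortening the chain toward that end is therefore expected to move the number down by a moderate step, beyond the scatter. Compound 4 is estimated at 6000 nM in this assay, within 2000 nM to 18000 nM. The step of a 3.4-fold lower number from compound 3 to compound 4 (0.53 log units; beyond the scatter) is expected downward.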

Compound 4, half-maximal inhibitory concentration: 17800 nM
Estimate against measurement, compound 4: 3.0-fold (0.47 log units) below, within the range that was stated.
By their numbers in this assay, from the lowest: compound 2; then compounds 4 and 3 (each within the scatter of the next). At a limit, above all of these: compound 1.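

Hydrogen in place of propyl on this saturated chain carbon leaves this assay with a 1.1-fold lower number from compound 3 to compound 4 (0.06 log units; within the scatter), so these two chain lengths cannot be told apart. The large change lies at the triple-bonded carbon, where the listed replacement of hydrogen by propyl gives an 8.9-fold higher number from compound 2 to compound 4 (0.95 log units; beyond the scatter). Nothing at hand explains this pattern. Going by these compounds, whether a methyl or ethyl group on the triple-bonded carbon would read closer to compound 2 or to compound 4 remains open. So does the outcome of placing an amine or a carboxylic acid on the chain.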